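A few compounds are considered here, and "the series" means these few. Any claim that something is new, unique, unknown or untested is made for them only; others in the source may bear on it.

In a functional assay on U-87MG ATCC cells (Homo sapiens) for cytotoxicity, read by MTT assay, with a stated time of 72 h (on this read-out higher numbers stand for weaker inhibition and lower numbers for stronger inhibition), compound 1 `CN(C)CCn1cnnc1-c1cc(Oc2ccc(NC(=O)N/N=C/c3ccc(Cl)cc3Cl)cc2F)ccn1` gives 2330 nM. Among the measured compounds shown here, compound 2 `CN(C)CCn1cnnc1-c1cc(Oc2ccc(NC(=O)N/N=C/c3ccc(O)cc3)cc2F)ccn1` gives 7750 nM in this assay, the higher of the two numbers recorded so far; the single step, a 3.3-fold higher number from compound 1 to compound 2 (0.52 log units; beyond the scatter), is the only measured change. Compound 3 `CN(C)CCn1cnnc1-c1cc(Oc2ccc(NC(=O)N/N=C/c3cccc(O)c3)cc2F)ccn1` is the next member: 3-hydroxyphenyl in place of 4-hydroxyphenyl on a carbon with a double bond to nitrogen. For the measured compounds named here, no measured step moves a hydroxyl around the ring; the one step available exchanges the whole aryl substituent, and it stayed modest. On that basis the step from compound 2 to compound 3 in this assay is expected to stay within the scatter or at most be small, with no clear direction, an expectation written as a 1.1-fold lower number from compound 2 to compound 3 (0.04 log units; within the scatter). Compound 3 is therefore estimated at 7000 nM in this assay, within a range of 2800 nM to 17500 nM.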

Compound 3, half-maximal inhibitory concentration: > 100000 nM
Compound 3 was reported as a limit; the forecaster's own chance of this, stated with the estimate: 5%; middle value at least 14-fold (1.15 log units) from the limit.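

In this assay, 3-hydroxyphenyl in place of 4-hydroxyphenyl on a carbon with a double bond to nitrogen gives an at least 12-fold higher number from compound 2 to compound 3 (1.11 log units; beyond the scatter), although both groups have the same heavy-atom, donor and acceptor counts. The position therefore responds to where the hydroxyl stands on the aryl ring, and not only to which aryl substituent is present, as the exchange of the whole group had suggested: against the 2,4-dichlorophenyl group the change is an at least 42-fold higher number from compound 1 to compound 3 (1.63 log units; beyond the scatter). The value of compound 3 is a limit and not a number, so the true size of both steps stays unknown: the limit of > 100000 nM in this assay, at which 1 of the 3 values shown sits.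

The compounds shown do not tell why the 3-hydroxyphenyl group behaves so differently. As far as these compounds go, whether the same response holds for 3-methoxyphenyl, 3-aminophenyl or an unsubstituted phenyl at this position remains open.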